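The source may hold more compounds than are shown below. What is called first, only, known or untested is meant among the compounds shown, and "the series" means these compounds.

Compound 1 `CCC(C)n1cnc2c(NCc3ccc(C(=O)Nc4ccccc4N)cc3)nc(Cl)nc21` and compound 2 `CC(C)n1cnc2c(NCc3ccc(C(=O)Nc4ccccc4N)cc3)nc(Cl)nc21` share one core and differ only in a side group. In a functional assay on HepG2 cells (Homo sapiens) for antiproliferative activity, read by CCK-8 assay, with a stated time of 72 h, tested at 2 uM (on this read-out higher numbers stand for a stronger effect at the one concentration tested and lower numbers for a weaker effect), compound 1 gives 45%, while compound 2 gives 63.8%, which is a number 18.8 percentage points higher from compound 1 to compound 2 (beyond the scatter). Compound 2 therefore stands highest of the two numbers. Compound 3 `Nc1ccccc1NC(=O)c1ccc(CNc2nc(Cl)nc3c2ncn3C2CCCC2)cc1` differs from compound 2 in one place: cyclopentyl in place of isopropyl on an aromatic nitrogen. Going by the values given here, the only step that bears on this change removed a methyl from the side group and raised the number; here carbon is added instead, so compound 3 is expected to sit somewhat lower, with a number 8.8 percentage points lower from compound 2 to compound 3 (within the scatter). Compound 3 is thus estimated at 55%, within a range from 35% to 75%.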

Compound 3, a percentage reported as inhibition, at one concentration (the size of the read-out at that concentration, not a potency): 54.7%
Estimate against measurement, compound 3: 0.3 percentage points above; the range from low to high includes it.
By their numbers in this assay, from the lowest: compounds 1, 3 and 2 (each within the scatter of the next, the first and the last beyond it).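

Swapping isopropyl for cyclopentyl on this aromatic nitrogen gives a number 9.1 percentage points lower from compound 2 to compound 3 (within the scatter), and swapping sec-butyl for cyclopentyl gives a number 9.7 percentage points higher from compound 1 to compound 3 (within the scatter). A side group closed into a five-membered ring of carbon only therefore cannot be told apart from either open chain, even though those two chains differ from each other beyond the scatter. Nothing available explains these numbers. Still open, going by these compounds, is how a smaller methyl group, a six-membered carbon ring or a chain ending in an amine would read at this position.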